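This account rests on a few compounds, and the source may have more. Where it says the series, first, only, none or still open, it means among the compounds named here.

Three compounds have been measured so far in an ADME assay on HT-29 cells (Homo sapiens) for cytotoxicity, read by MTT assay, with a stated time of 72 h; a lower number here means a stronger inhibitor, a higher number a weaker inhibitor:

Compound 1 `C=CC(=O)Nc1cc(Nc2ncc3ncn(-c4ccc(C)cc4)c3n2)c(OC)cc1N(C)CCN(C)C`: 9230 nM
Compound 2 `C=CC(=O)Nc1cc(Nc2ncc3ncn(-c4ccc(CC)cc4)c3n2)c(OC)cc1N(C)CCN(C)C`: 8180 nM
Compound 3 `C=CC(=O)Nc1cc(Nc2ncc3ncn(-c4ccc(Br)cc4)c3n2)c(OC)cc1N(C)CCN(C)C`: 1460 nM

Compound 2 stands second highest of these three numbers. Its nearest neighbour is compound 1, with the step of a 1.1-fold lower number from compound 1 to compound 2 (0.05 log units; within the scatter), a gap that lies within the scatter; its furthest neighbour is compound 3, reached by the step of a 5.6-fold lower number from compound 2 to compound 3 (0.75 log units; beyond the scatter).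

Compound 4 `C=CC(=O)Nc1cc(Nc2ncc3ncn(-c4ccc(F)c(Cl)c4)c3n2)c(OC)cc1N(C)CCN(C)C` has not yet been measured. Its difference from compound 2 is 3-chloro-4-fluorophenyl in place of 4-ethylphenyl on an aromatic nitrogen. Among the measured compounds shown here, two measured steps bear on this: the exchanges that put bromo in place of methyl, a 6.3-fold lower number from compound 1 to compound 3 (0.80 log units; beyond the scatter), and bromo in place of ethyl, a 5.6-fold lower number from compound 2 to compound 3 (0.75 log units; beyond the scatter), both modest, both beyond the scatter, and both toward a lower number. The step of a 1.1-fold lower number from compound 1 to compound 2 (0.05 log units; within the scatter) shows that going from methyl to ethyl changed little. The incoming group carries chlorine and fluorine rather than bromo, so the size of the effect is uncertain, but a lower number is expected because of a 5.6-fold lower number from compound 2 to compound 3 (0.75 log units; beyond the scatter).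

Compound 4 is therefore estimated at about 3000 nM, in a range from 1200 nM to 8000 nM. The expected step is a 2.7-fold lower number from compound 2 to compound 4 (0.44 log units; beyond the scatter).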

Compound 4, half-maximal inhibitory concentration: 1610 nM
For compound 4 the middle estimate is 1.9-fold (0.27 log units) above the measured one; low and high end bracket the measured number.
By their numbers in this assay, from the lowest: compounds 3 and 4 (each within the scatter of the next); then compounds 2 and 1 (each within the scatter of the next).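

In this assay, among the compounds shown here, putting 3-chloro-4-fluorophenyl on the aromatic nitrogen gives a 5.1-fold lower number from compound 2 to compound 4 (0.71 log units; beyond the scatter) and a 5.7-fold lower number from compound 1 to compound 4 (0.76 log units; beyond the scatter), so the drop from the alkyl-bearing compounds is not confined to the one bromo compound. Against 4-bromophenyl, the exchange gives a 1.1-fold higher number from compound 3 to compound 4 (0.04 log units; within the scatter), which means that this position tolerates one bromine or a chlorine and fluorine pair with no difference that can be told from the scatter, even though the two groups differ in the number and kind of their halogen atoms. Across these four compounds, the two with halogens on the ring both lie at lower numbers than the two with methyl or ethyl, and none of the four goes against this pattern.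

No evidence is available here to explain why the halogen-bearing rings give lower numbers.

The compounds shown also leave open whether chlorine or fluorine alone would give the same result, and whether a ring carrying an amine or a carboxylic acid at this position would stay with the halogen pair or with the alkyl pair.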